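The source may hold more compounds than are shown below. What is called first, only, known or untested is meant among the compounds shown, and "the series" means these compounds.

Values in an ADME assay on A549 cells (Homo sapiens) for cytotoxicity, read by resazurin assay, with a stated time of 48 h; a higher number here means that more compound is tolerated, a lower number that less compound is tolerated:
- compound 1 `CN(C)c1ccc(NC(=O)c2cc(Cl)ccc2O)c(Cl)c1`: 85100 nM
- compound 2 `O=C(Nc1ccc(NCc2ccncc2)cc1Cl)c1cc(Cl)ccc1O`: 65300 nM
- compound 3 `O=C(Nc1ccc(NCc2cccnc2Cl)cc1Cl)c1cc(Cl)ccc1O`: 101000 nM

Compound 3 stands at 101000 nM, but the three values are not separated. The steps of a 1.2-fold higher number from compound 1 to compound 3 (0.07 log units; within the scatter), a 1.5-fold higher number from compound 2 to compound 3 (0.19 log units; within the scatter) and a 1.3-fold lower number from compound 1 to compound 2 (0.12 log units; within the scatter) all lie within the scatter.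

Next is compound 4 `O=C(Nc1ccc(NCCCO)cc1Cl)c1cc(Cl)ccc1O`, not yet measured in this assay. The change is 2-hydroxyethyl in place of 2-chloropyridin-3-yl on a saturated chain carbon bound to a nitrogen on an aromatic ring. The same difference also reads as (2-chloropyridin-3-yl)methyl to 3-hydroxypropyl.

Going by the values given here, two measured steps bear on it. The step of a 1.5-fold higher number from compound 2 to compound 3 (0.19 log units; within the scatter) exchanged one ring-bearing group for another on that chain carbon. The step of a 1.2-fold higher number from compound 1 to compound 3 (0.07 log units; within the scatter) set ((2-chloropyridin-3-yl)methyl)amino in place of dimethylamino, a group with no ring, so it comes closest to removing the ring. Neither step left the scatter. Among the compounds with values here, no compound with a hydroxyl-bearing chain has been measured, so this read-across is loose, and no change beyond the scatter is expected.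

The expected step is a 1.3-fold lower number from compound 3 to compound 4 (0.10 log units; within the scatter).

For compound 4 the estimated value is 80000 nM, with an expected range of 40000 nM to 160000 nM.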

Compound 4, half-maximal cytotoxic concentration: 106000 nM
Compound 4: the middle estimate sits 1.3-fold (0.12 log units) below what was measured; the measured number falls inside the stated range.
By their numbers in this assay, from the lowest: compounds 2, 1, 3 and 4 (each within the scatter of the next).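

In this assay, the two ring-bearing groups on the saturated chain carbon bound to a nitrogen on an aromatic ring can give way to 2-hydroxyethyl, which has no ring, without leaving the scatter: (a 1.0-fold higher number from compound 3 to compound 4 (0.02 log units; within the scatter)) for 2-chloropyridin-3-yl and (a 1.6-fold higher number from compound 2 to compound 4 (0.21 log units; within the scatter)) for pyridin-4-yl. On an aromatic carbon, (3-hydroxypropyl)amino also cannot be told apart from dimethylamino (a 1.2-fold higher number from compound 1 to compound 4 (0.10 log units; within the scatter)), so the position has now carried a hydroxyl-bearing chain as well as both pyridine-bearing groups, and all four compounds remain unseparated. No supporting data are available to explain this lack of separation.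

Still open, from the compounds shown here alone, is whether a carboxylic acid or an amine in place of 2-hydroxyethyl, or a longer chain, would give a step beyond the scatter in this assay. Going by these compounds, all four compounds also share one core, so the effect of any change to it remains unknown.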